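This account rests on a few compounds, and the source may have more. Where it says the series, first, only, none or still open, it means among the compounds named here.

Measured so far:
compound 1 `CCc1ccccc1OS(=O)(=O)c1cccc(NC(=O)NCCCCl)c1` — 25000 nM
compound 2 `CCc1ccccc1OS(=O)(=O)c1ccc(NC(=O)NCCCCl)cc1` — 15000 nM

In a functional assay on MCF7 cells (Homo sapiens) for cytotoxicity, read by sulforhodamine B assay, with a stated time of 48 h (on this read-out lower numbers stand for stronger inhibition and higher numbers for weaker inhibition), compound 2 gives 15000 nM, and compound 1 gives 25000 nM. The two numbers lie within the scatter of each other, so neither compound is set apart. Compound 3 `O=C(NCCCCl)Nc1ccc(S(=O)(=O)Oc2ccc(O)cc2)cc1` is not yet measured. Its change from compound 2: 4-hydroxyphenyl in place of 2-ethylphenyl on an oxygen. Within the data shown here, no measured pair covers a change of this kind, so nothing points to a step beyond the scatter in either direction. For compound 3 in this assay the expected value is 20000 nM (range 7000 nM to 60000 nM). The step expected is a 1.3-fold higher number from compound 2 to compound 3 (0.12 log units; within the scatter), not beyond the scatter.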

Compound 3, half-maximal inhibitory concentration: 51000 nM
For compound 3 the middle estimate is 2.6-fold (0.41 log units) below the measured one; low and high end bracket the measured number.
By their numbers in this assay, from the lowest: compounds 2 and 1 (each within the scatter of the next); then compound 3.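

On the oxygen whose other neighbour is the sulfonyl sulfur, a change of group now moves the number beyond the scatter. In this assay, 4-hydroxyphenyl in place of 2-ethylphenyl gives a 3.4-fold higher number from compound 2 to compound 3 (0.53 log units; beyond the scatter), a modest weakening that shows this position is not indifferent to the group it carries. No data at hand account for the step.

Left open is whether the step follows the arrival of the hydroxy group or the departure of the ethyl group, which change together here. Also open, going by these compounds, is how a plain phenyl or a 4-methoxyphenyl on that oxygen would read.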